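The source may report more compounds than this note shows. Statements on the series, on what has been measured and on what is new or still open speak of the compounds shown alone.

Measured compounds:
compound 1 `COc1ccc(-c2cnc3nc(N)nc(N4CCN(C(=O)Nc5ccc(C)cc5)CC4)c3n2)cc1OC`; in a functional assay on cells (T-cell, Homo sapiens) for inhibition (on this read-out lower numbers stand for stronger inhibition and higher numbers for weaker inhibition), compound 1 gives 0.8 nM.
compound 2 `COc1ccc(-c2cnc3nc(N)nc(N4CCN(c5ccc(F)cc5)CC4)c3n2)cc1OC`; compound 2 gives 100 nM.
compound 3 `COc1ccc(-c2cnc3nc(N)nc(OC(C)C)c3n2)cc1OC`; compound 3 gives 400 nM.

Compound 2 stands second highest of the three numbers: compound 3 sits one step above it, beyond the scatter, and compound 1 sits far below it. Among the compounds with values here, the only one-place change among the measured compounds is a 130-fold higher number from compound 1 to compound 2 (2.10 log units; beyond the scatter), a large step.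

Compound 4 `COc1ccc(-c2cnc3nc(N)nc(N4CCN(C(=O)Nc5ccc(C#N)cc5)CC4)c3n2)cc1OC` differs from compound 2 by (4-cyanophenyl)carbamoyl in place of 4-fluorophenyl on an amine nitrogen in a ring. The measured step that bears on this change is a 130-fold higher number from compound 1 to compound 2 (2.10 log units; beyond the scatter), which runs in the opposite direction through the same place on the ring nitrogen: removing the (4-methylphenyl)carbamoyl group in favour of 4-fluorophenyl raised the number greatly. Compound 4 restores a carbamoyl group, now carrying a 4-cyanophenyl ring. Within the data shown here, no measured compound tells how a 4-cyanophenyl ring compares with a 4-methylphenyl ring, so that part of the change is unsupported and the expected size is uncertain; the expectation from compound 1 is a large step downward, a 50-fold lower number from compound 2 to compound 4 (1.70 log units; beyond the scatter), in this assay. Compound 4 is therefore estimated at 2 nM, within 0.5 nM to 10 nM.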

Compound 4, half-maximal inhibitory concentration: 74 nM
Compound 4: the middle estimate sits 37-fold (1.57 log units) below what was measured; the measured number lies above the stated range.
By their numbers in this assay, from the lowest: compound 1; then compounds 4 and 2 (each within the scatter of the next); then compound 3.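

In this assay, a carbamoyl group on the ring nitrogen does not by itself bring the low number of compound 1: the printed step is a 1.4-fold lower number from compound 2 to compound 4 (0.13 log units; within the scatter) when (4-cyanophenyl)carbamoyl stands in place of 4-fluorophenyl. Within the data shown here, the large difference instead appears within the carbamoyl pair, where a 93-fold higher number from compound 1 to compound 4 (1.97 log units; beyond the scatter) comes with cyano in place of methyl on an aromatic carbon as the only change. No measurement shown gives a reason for this step.

On these data alone, whether methyl is the unusual substituent or cyano is the disfavoured one stays open, since a hydrogen, chlorine, methoxy or ethyl group at that aromatic carbon would be needed to place the two. Also open, as far as these compounds go, is whether a longer chain or an amine on that aromatic ring would keep the low number of compound 1.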